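Working notes: replacing the 4-fluorophenyl of compound 2

The source may report more compounds than this note shows. Statements on the series, on what has been measured and on what is new or still open speak of the compounds shown alone.

Among the measured compounds shown here, in a functional assay on Jurkat cells (Homo sapiens) (a lower number here means a stronger inhibitor, a higher number a weaker inhibitor), compound 2 `C[C@H](NC(=O)C(=O)NCc1ccc(F)cc1)C(=O)N[C@@H](CC(=O)O)C(=O)COc1c(F)c(F)cc(F)c1F` gives 197 nM, the higher of the two numbers so far, and compound 1 `C[C@H](NC(=O)C(=O)NCC1(c2ccccc2)CC1)C(=O)N[C@@H](CC(=O)O)C(=O)COc1c(F)c(F)cc(F)c1F` gives 27 nM. Compound 3 `Cc1ccc(CNC(=O)C(=O)N[C@@H](C)C(=O)N[C@@H](CC(=O)O)C(=O)COc2c(F)c(F)cc(F)c2F)c(C)c1` carries 2,4-dimethylphenyl in place of 4-fluorophenyl on a saturated chain carbon bound to an amide-type nitrogen.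

For the measured compounds named here, the only measured step, a 7.3-fold higher number from compound 1 to compound 2 (0.86 log units; beyond the scatter), exchanges 1-phenylcyclopropyl for 4-fluorophenyl at that same place. Going by the values given here, it shows that the number can move with the group there, but it is a different exchange, and no measured compound carries 2,4-dimethylphenyl. It therefore bears on the new change only indirectly. A smaller step towards a lower number is expected, and it may not exceed the scatter. The expected change is a 1.8-fold lower number from compound 2 to compound 3 (0.25 log units; within the scatter). For compound 3 the estimated value is 110 nM, with an expected range of 40 nM to 300 nM.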

Compound 3, half-maximal inhibitory concentration: > 10000 nM
Compound 3: a limit, no number (the forecaster's own chance of this, stated with the estimate: 2%); middle value at least 90-fold (1.95 log units) away from the limit.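

In this assay compound 3 gives > 10000 nM as a limit of the assay and not a number. Among the compounds shown here, exchanging 4-fluorophenyl for 2,4-dimethylphenyl on a saturated chain carbon bound to an amide-type nitrogen gives an at least 50-fold higher number from compound 2 to compound 3 (1.70 log units; beyond the scatter) even though one six-membered aromatic ring of carbon remains there, so keeping such a ring does not by itself hold the number near those of the earlier compounds. Exchanging 1-phenylcyclopropyl for 2,4-dimethylphenyl gives an at least 370-fold higher number from compound 1 to compound 3 (2.56 log units; beyond the scatter) and thus widens the span at this place well past the earlier 7.3-fold higher number from compound 1 to compound 2 (0.86 log units; beyond the scatter) step.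

On these data alone, whether 2-methylphenyl or 4-methylphenyl alone would read like compound 2 or like compound 3 stays open. The compounds shown also leave open how far compound 3 lies past its limit.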